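The source may hold more compounds than are shown below. What is called first, only, known or untested is meant among the compounds shown, and "the series" means these compounds.

Measured in an assay on HEK293 cells for positive allosteric modulation of metabotropic glutamate receptor 2 (Rattus norvegicus), read by thallium flux, with a stated time of 2.5 min; on this read-out higher numbers stand for larger maximal responses and lower numbers for smaller maximal responses:
compound 1 `COC(=O)c1ccc(OCCCCOc2ccc(C(=O)CC3CCCC3)c(O)c2C)cc1`: 12.2%
compound 2 `COC(=O)c1ccc(OCCCCOc2ccc(C(=O)CC(C)C)c(O)c2C)cc1`: 16.4%
compound 3 `CCC(=O)c1ccc(OCCCCOc2ccc(C(=O)O)cc2C)c(C)c1O`: 86.6%

Compound 2 stands second highest of the three numbers. Its nearest neighbour is compound 1, and the step of a number 4.2 percentage points higher from compound 1 to compound 2 (within the scatter) lies within the scatter, while compound 3 lies far higher, beyond the scatter. The next compound, compound 4 `Cc1c(OCCCCOc2ccc(C(=O)O)c(Cl)c2)ccc(C(=O)CC(C)C)c1O`, differs from compound 2 in one place: 4-carboxy-3-chlorophenyl in place of 4-(methoxycarbonyl)phenyl on an oxygen on a saturated carbon. Among the measured compounds shown here, the only measured step, a number 4.2 percentage points higher from compound 1 to compound 2 (within the scatter), concerns the group on the saturated chain carbon bound to the carbonyl carbon and leaves the ester end untouched, so it does not bear on this change. For the measured compounds named here, no single-change step links compound 2 to compound 3. Compound 3 does carry the carboxy group that enters here and gives 86.6%. Compound 2 gives 16.4%. Going by the values given here, on that showing an upward step in this assay is expected for compound 4; the chlorine has no precedent, which widens the range. Compound 4 is estimated at 60% (range 25% to 95%). This means an expected step of a number 43.6 percentage points higher from compound 2 to compound 4 (beyond the scatter).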

Compound 4, largest response reached (reported as percent of maximum), in percent of the reference or control that the assay uses: 80.5%
The estimate for compound 4 lay 20.5 percentage points below the measured number; the measured number falls inside the stated range.
By their numbers in this assay, from the lowest: compounds 1 and 2 (each within the scatter of the next); then compounds 4 and 3 (each within the scatter of the next).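

In this assay, 4-carboxy-3-chlorophenyl in place of 4-(methoxycarbonyl)phenyl on an oxygen on a saturated carbon gives a number 64.1 percentage points higher from compound 2 to compound 4 (beyond the scatter). The only earlier single-change step, a number 4.2 percentage points higher from compound 1 to compound 2 (within the scatter), concerns the group on the saturated chain carbon bound to a carbonyl carbon, so this is the first single change shown that moves the largest response beyond the scatter, and the first read at this place. Nothing available gives a measured reason for the size of this step.

The change swaps the methyl ester for a carboxylic acid and adds chlorine in one move, so the compounds shown do not separate the two contributions. A plain 4-carboxyphenyl group, or a tetrazole in place of the carboxylic acid, would test which feature the response depends on.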